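The source may report more compounds than this note shows. Statements on the series, on what has been measured and on what is new or still open speak of the compounds shown alone.

In an ADME assay on the whole organism (Rattus norvegicus, strain Sprague-Dawley), read by LC-MS, with stated times of 5 min and 24 h, at a dose of 5 mg/kg by the oral route (on this read-out higher numbers stand for a longer-lived compound and lower numbers for a shorter-lived compound), compound 2 (`CO[C@H]1CCN(c2cc(NC(=O)N3CCCc4cc(CN5CCOCC5=O)c(C=O)nc43)ncc2C#N)C1`) gives 2.6 h. Two close relatives stand near it: compound 3 (`COCCNc1cc(NC(=O)N2CCCc3cc(CN4CC[C@H](OC)C4=O)c(C=O)nc32)ncc1C#N`) at 2.9 h and compound 1 (`N#Cc1cnc(NC(=O)N2CCCc3cc(CN4CCOCC4=O)c(C=O)nc32)cc1S[C@H]1CCOC1`) at 3.5 h. The gaps from compound 2 to both lie within the usual scatter of repeated measurements, so these numbers do not separate compound 2 from either relative.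

Compound 4 (`N#Cc1cnc(NC(=O)N2CCCc3cc(CN4CCOCC4=O)c(C=O)nc32)cc1S[C@@H]1CCOC1`) keeps the core of compound 2 and alters one group, on an aromatic carbon of a six-membered aromatic ring with 1 nitrogen, ortho to a cyano group and opposite the ring nitrogen: (oxolan-3-yl)sulfanyl in place of 3-methoxypyrrolidin-1-yl on an aromatic carbon. In words, (oxolan-3-yl)sulfanyl comes in place of 3-methoxypyrrolidin-1-yl.

Among the compounds with values here, only one measured step bears on this change: a 1.3-fold lower number from compound 1 to compound 2 (0.13 log units; within the scatter). It exchanges the same two groups in the other direction, and it lies within the scatter. Turned around, it points weakly towards a slightly higher number, but no measurement here shows how the arrangement at the stereocentre of the incoming group counts. The expected step is therefore small and stays within the scatter, a 1.2-fold higher number from compound 2 to compound 4 (0.09 log units; within the scatter). In this assay compound 4 is estimated at 3.2 h, with an expected range from 2 h to 5 h.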

Compound 4, mean residence time: 3.65 h
The estimate for compound 4 lay 1.1-fold (0.06 log units) below the measured number, and the stated range covers the measured number.
By their numbers in this assay, from the lowest: compounds 2, 3, 1 and 4 (each within the scatter of the next).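

In this assay, the exchange of 3-methoxypyrrolidin-1-yl for (oxolan-3-yl)sulfanyl now has a second reading, a 1.4-fold higher number from compound 2 to compound 4 (0.15 log units; within the scatter), and, like the earlier 1.3-fold lower number from compound 1 to compound 2 (0.13 log units; within the scatter), it stays within the scatter. So, with either arrangement of the incoming group, this change at the carbon opposite the ring nitrogen does not separate the compounds. The new information concerns the stereocentre of the incoming group, which the earlier compounds could not address: a 1.0-fold higher number from compound 1 to compound 4 (0.02 log units; within the scatter) also lies within the scatter, so S or R at that saturated ring carbon makes no visible difference here, and this reading is a clean one because only a single feature changes: the fact that compounds 1 and 4 differ only in the configuration as drawn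

On these data alone, the two groups compared at this position are both five-membered rings with one hetero atom, so it remains open whether something quite different there, such as a carboxylic acid, a primary amine or a longer chain, would move the residence time beyond the scatter. As far as these compounds go, it is also open whether the indifference to the stereocentre holds in any read-out other than this assay.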